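The compounds below may be only part of what the source reports. "The series", "measured", "known", "first", "only" and "open" are said of these compounds alone.

Measured in a functional assay on MDA-MB-231 cells (Homo sapiens) for cytotoxicity, read by MTT assay (on this read-out higher numbers stand for weaker inhibition and lower numbers for stronger inhibition), so far:
- compound 1 `COc1ccc(-c2cn(-c3ccc(Oc4ccccc4)cc3)nn2)cc1` gives > 100 nM (a limit, not a number)
- compound 2 `COc1ccc(-n2cc(-c3cc(O)cc(O)c3)nn2)c(OC)c1` gives 10000 nM (the only true number)
- compound 3 `COc1cc(-c2cn(-c3ccc(Oc4ccccc4)cc3)nn2)ccc1O` gives "not determined" (no result reported) (no result)

As far as these compounds go, compound 3 has no number of its own, so its place in this assay stays open. Compound 1, which carries the same phenoxy group, offers only the limit of > 100 nM in this assay, at which 1 of the 3 values shown sits, and nothing firmer.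

The next compound is compound 4 `COc1cc(-c2cn(-c3ccc(OC(F)(F)F)cc3)nn2)ccc1O`. It changes phenoxy to trifluoromethoxy, with trifluoromethyl in place of phenyl on an oxygen on an aromatic ring and the rest of compound 3 untouched.

Among the measured compounds shown here, without a number for compound 3 no step can be sized, and no measured pair shows what this exchange does. The expectation in this assay is therefore a step no larger than the scatter, with no direction favoured. For the measured compounds named here, the only numeric anchor is compound 2 at 10000 nM, so the estimate rests on it loosely and stays wide.

For compound 4 the expected value is 3000 nM, with an estimated range from 200 nM to 30000 nM as the likely span.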

Compound 4, half-maximal inhibitory concentration: 10000 nM
Compound 4: the middle estimate sits 3.3-fold (0.52 log units) below what was measured; the range from low to high includes it.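

Among the compounds shown here, compound 3 has no reported result in this assay, so no step from it to compound 4 can be read. What the exchange of phenoxy for trifluoromethoxy does in this assay stays open, and compound 1, which carries the phenoxy group, provides only a limit: the limit of > 100 nM in this assay, at which 1 of the 4 values shown sits.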